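A few compounds are considered here, and "the series" means these few. Any claim that something is new, unique, unknown or untested is made for them only; others in the source may bear on it.

Measured so far in a functional assay on PC-12 cells (Rattus norvegicus) for cytotoxicity, read by MTT assay, with stated times of 2 h and 24 h, tested at 10 uM; a lower number here means a weaker effect, a higher number a stronger effect of the compound at the concentration tested:
compound 1 `Oc1cc(C(F)(F)F)ccc1-c1nc(-c2ccccc2O)n(-c2ccccc2Cl)n1`: 102%
compound 2 `Oc1cc(C(F)(F)F)ccc1-c1nc(-c2ccccc2O)n(-c2cccc(F)c2)n1`: 98.3%
compound 3 `COc1cccc(-n2nc(-c3ccc(C(F)(F)F)cc3O)nc2-c2ccccc2O)c1`: 106%

Compound 3 holds the highest of the three numbers, but its gaps to the others are small: a number 4 percentage points higher from compound 1 to compound 3 (within the scatter) and a number 7.7 percentage points higher from compound 2 to compound 3 (within the scatter), both within the scatter. Within the data shown here, on these numbers no compound can be called stronger or weaker than another.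

Compound 4 `Oc1cc(C(F)(F)F)ccc1-c1nc(-c2ccccc2O)n(-c2ccc(F)cc2F)n1` is not yet measured. It differs from compound 3 on the aromatic nitrogen of the shared core: 2,4-difluorophenyl in place of 3-methoxyphenyl on an aromatic nitrogen.

Among the measured compounds shown here, two measured steps bear on this place, both exchanges of the aryl group on that aromatic nitrogen: a number 3.7 percentage points lower from compound 1 to compound 2 (within the scatter) and a number 4 percentage points higher from compound 1 to compound 3 (within the scatter). A third, a number 7.7 percentage points higher from compound 2 to compound 3 (within the scatter), is methoxy in place of fluoro on an aromatic carbon of that aryl group. None moved the read-out beyond the scatter. For the measured compounds named here, no measured compound carries the 2,4-difluorophenyl group, so the step is not covered exactly; the expectation rests on the small size of all three steps. No shift beyond the scatter is expected in this assay, and the estimated step is a number 6 percentage points lower from compound 3 to compound 4 (within the scatter). Compound 4 is expected to give 100%, between 91% and 109%.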

Compound 4, a percentage reported as activity, at one concentration (the size of the read-out at that concentration, not a potency): 97.9%
Estimate against measurement, compound 4: 2.1 percentage points above, and the stated range covers the measured number.
By their numbers in this assay, from the lowest: compounds 4, 2, 1 and 3 (each within the scatter of the next).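

In this assay, among these compounds, the aromatic nitrogen now carries 2,4-difluorophenyl, the first group with two fluorine atoms on that ring, and the steps to it are all small: a number 8.1 percentage points lower from compound 3 to compound 4 (within the scatter), a number 0.4 percentage points lower from compound 2 to compound 4 (within the scatter) and a number 4.1 percentage points lower from compound 1 to compound 4 (within the scatter). Neither the second fluorine nor the absence of the methoxy oxygen separates compound 4 from compound 1, compound 2 or compound 3. No measurement shown here explains this lack of separation.

On these data alone, all four compounds carry a halogen- or methoxy-substituted phenyl on that nitrogen, so the reach of this tolerance remains open. A carboxylic acid or an amine on that phenyl, or a saturated alkyl chain in its place, could still shift the read-out.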